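Morpholine urea at the proline nitrogen: an expected result

The source may report more compounds than this note shows. Statements on the series, on what has been measured and on what is new or still open speak of the compounds shown alone.

Of the compounds shown here, three sharing one core have been measured in a functional assay on U2OS cells for antagonist activity at proto-oncogene Wnt-3 (Homo sapiens), read by a luciferase reporter, with a stated time of 18 h; a higher number here means that more compound is needed for the effect, a lower number that less compound is needed. Compound 1 `CC(C)C(=O)N1CCC[C@H]1C(=O)N1CCC(NS(=O)(=O)c2cc(S(=O)(=O)c3ccccc3)ccc2C(F)(F)F)CC1` gives 90 nM, compound 2 `CC(C)(C)C(=O)N1CCC[C@H]1C(=O)N1CCC(NS(=O)(=O)c2cc(S(=O)(=O)c3ccccc3)ccc2C(F)(F)F)CC1` gives 270 nM, and compound 3 `CN(C)C(=O)N1CCC[C@H]1C(=O)N1CCC(NS(=O)(=O)c2cc(S(=O)(=O)c3ccccc3)ccc2C(F)(F)F)CC1` gives 160 nM. Compound 3 therefore stands second highest of the three numbers; its nearest neighbour is compound 2, its furthest is compound 1, and both of those gaps lie within the scatter. Compound 4 `O=C([C@@H]1CCCN1C(=O)N1CCOCC1)N1CCC(NS(=O)(=O)c2cc(S(=O)(=O)c3ccccc3)ccc2C(F)(F)F)CC1` is not yet measured; it differs from compound 3 by morpholin-4-yl in place of dimethylamino on a carbonyl carbon. For the measured compounds named here, the steps that bear on this change are those at the same carbonyl carbon: a 1.8-fold higher number from compound 1 to compound 3 (0.25 log units; within the scatter) and a 1.7-fold lower number from compound 2 to compound 3 (0.23 log units; within the scatter), neither beyond the scatter, while the one step beyond the scatter, a 3.0-fold higher number from compound 1 to compound 2 (0.48 log units; beyond the scatter), was modest. On that basis compound 4 is expected to show no step beyond the scatter in this assay, with a 1.3-fold higher number from compound 3 to compound 4 (0.10 log units; within the scatter) as the estimated shift. The estimate for compound 4 is 200 nM, expected to fall between 80 nM and 500 nM.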

Compound 4, half-maximal effective concentration: 280 nM
The estimate for compound 4 lay 1.4-fold (0.15 log units) below the measured number; the range from low to high includes it.
By their numbers in this assay, from the lowest: compounds 1, 3, 2 and 4 (each within the scatter of the next, the first and the last beyond it).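

In this assay the carbonyl carbon on the proline nitrogen takes morpholin-4-yl, with its six-membered non-aromatic ring and one hydrogen-bond acceptor, in place of dimethylamino with a 1.8-fold higher number from compound 3 to compound 4 (0.24 log units; within the scatter) and in place of tert-butyl with a 1.0-fold higher number from compound 2 to compound 4 (0.02 log units; within the scatter) as the readings, so neither swap separates the compounds. Only the isopropyl group stands apart from morpholin-4-yl, with a 3.1-fold higher number from compound 1 to compound 4 (0.49 log units; beyond the scatter) being a modest step and the same in size as a 3.0-fold higher number from compound 1 to compound 2 (0.48 log units; beyond the scatter) for the tert-butyl group. Nothing offered here explains these steps.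

From the compounds shown here alone, whether a ring amine such as piperazin-1-yl, or a carboxylic acid carried on the morpholine ring, would behave the same way at this carbonyl carbon stays open. So does the effect of a longer open chain such as diethylamino.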